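A triazole tail in place of an imidazole tail

A few compounds are considered here, and "the series" means these few. Any claim that something is new, unique, unknown or untested is made for them only; others in the source may bear on it.

Compound 1 `Cn1cc(C2=C(c3n[nH]c4ncccc34)C(=O)N(c3cccc4ccccc34)C2=O)c2ccccc21`, compound 2 `Cn1cc(C2=C(c3nn(CCCCn4ccnc4)c4ncccc34)C(=O)NC2=O)c2ccccc21`, compound 3 `Cn1cc(C2=C(c3nn(CCCCn4ccnc4)c4ncccc34)C(=O)N(c3ccccc3)C2=O)c2ccccc21`.

In a functional assay on K562 cells (Homo sapiens) for antiproliferative activity, read by MTT assay, with a stated time of 48 h (on this read-out higher numbers stand for weaker inhibition and lower numbers for stronger inhibition), compound 1 gives only a limit, > 100000 nM. Compound 2 gives 31800 nM, the higher of the two numbers. For the measured compounds named here, compound 3 gives 5030 nM, and the one measured step, a 6.3-fold lower number from compound 2 to compound 3 (0.80 log units; beyond the scatter), concerns the amide-type nitrogen in a ring. Compound 4 `Cn1cc(C2=C(c3nn(CCCn4cncn4)c4ncccc34)C(=O)NC2=O)c2ccccc21` differs from compound 2 elsewhere: 1H-1,2,4-triazol-1-yl in place of (1H-imidazol-1-yl)methyl on a saturated chain carbon, three bonds along the chain from an aromatic nitrogen. Going by the values given here, no measured step touches this chain, so the single step available offers no guide, and no change beyond the scatter is expected in this assay. Compound 4 is therefore estimated at 30000 nM, with a range from 10000 nM to 100000 nM. The expected step is a 1.1-fold lower number from compound 2 to compound 4 (0.03 log units; within the scatter).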

Compound 4, half-maximal inhibitory concentration: > 100000 nM
Compound 4: only a limit was reported (the forecaster's own chance of this, stated with the estimate: 20%); at least 3.3-fold (0.52 log units) between middle value and limit.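

In this assay, the tail at this position matters: 3-(1H-1,2,4-triazol-1-yl)propyl in place of 4-(1H-imidazol-1-yl)butyl gives an at least 3.1-fold higher number from compound 2 to compound 4 (0.49 log units; beyond the scatter). For the compounds shown here, until now, the only measured step concerned the amide-type nitrogen in a ring, so this is the first sign that the tail also affects the read-out. Compound 4 gives only a limit, so the full size of the step stays unknown: the limit of > 100000 nM in this assay, at which 2 of the 4 values shown sit.

The change alters the ring and the chain length together, and the compounds shown do not separate the two. As far as these compounds go, whether an amine or a carboxylic acid at the chain end would lower the number remains open.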